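Hydroxy in Place of Chloro: Expectation for Compound 3

The source may report more compounds than this note shows. Statements on the series, on what has been measured and on what is new or still open speak of the compounds shown alone.

compound 1 `CC1(C)[C@H]2CC[C@]1(C)N(Cc1cn(-c3ccc(C#N)cc3)nn1)C(=O)C2` — 50 nM
compound 2 `CC1(C)[C@H]2CC[C@]1(C)N(Cc1cn(-c3cccc(Cl)c3)nn1)C(=O)C2` — 60 nM

Of the compounds shown here, two have been measured in a functional assay on HepG2 cells (Homo sapiens) for inhibition, read by MTT assay, with a stated time of 24 h; on this read-out lower numbers stand for stronger inhibition and higher numbers for weaker inhibition. Compound 1 gives 50 nM, and compound 2 gives 60 nM. For the measured compounds named here, the single step between them, a 1.2-fold higher number from compound 1 to compound 2 (0.08 log units; within the scatter), exchanges one group on the six-membered aromatic ring for another without moving the number beyond the scatter. Compound 2 therefore stands with the highest of the two numbers, but its nearest neighbour, compound 1, lies within the scatter of it, so no order between the two can be read.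

Compound 3 `CC1(C)[C@H]2CC[C@]1(C)N(Cc1cn(-c3cccc(O)c3)nn1)C(=O)C2` is not yet measured. It differs from compound 2 in one place: hydroxy in place of chloro on an aromatic carbon. Going by the values given here, no measured step exchanges chloro for hydroxy, so the only guidance comes from the step of a 1.2-fold higher number from compound 1 to compound 2 (0.08 log units; within the scatter), which shows that changing the group on this ring left the number essentially where it was. On that basis the step from compound 2 to compound 3 is expected to stay within the scatter, a 1.2-fold higher number from compound 2 to compound 3 (0.07 log units; within the scatter). Compound 3 is estimated at 70 nM in this assay, with a range from 30 nM to 180 nM.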

Compound 3, half-maximal inhibitory concentration: 70 nM
For compound 3 middle estimate and measured number coincide at the digits printed; measured number inside the range.
By their numbers in this assay, from the lowest: compounds 1, 2 and 3 (each within the scatter of the next).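

In this assay, the exchange of chloro for hydroxy on an aromatic carbon, meta to a large group, reads as a 1.2-fold higher number from compound 2 to compound 3 (0.07 log units; within the scatter). For the compounds shown here, this is the only measured change made at this one atom of the six-membered aromatic ring while the rest of the molecule stays the same, and the entering hydroxy counts a hydrogen-bond donor and a hydrogen-bond acceptor where the leaving chloro counts neither, yet the step stays within the scatter. The wider exchange on the aromatic nitrogen, read as a 1.4-fold higher number from compound 1 to compound 3 (0.15 log units; within the scatter), also stays within the scatter, so 3-hydroxyphenyl and 4-cyanophenyl cannot be told apart here, and no measurement given here bears on why the number holds across these changes.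

The compounds shown leave open whether the number would also hold with an amine, a carboxylic acid or a longer chain such as methoxyethyl on this aromatic carbon, or with plain hydrogen there. They also leave open whether the number depends on the shared core, which is the same in all three compounds.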